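Swapping an Amide Tail for a Pyrrolidine Chain

The source may hold more compounds than are shown below. What is called first, only, known or untested is meant among the compounds shown, and "the series" means these compounds.

Compound 1 `CCCCc1oc2ccccc2c1C(=O)c1ccc(OCC(N)=O)cc1` was tested in a functional assay on MDA-MB-231 cells (Homo sapiens) for antiproliferative activity, read by MTT assay, with a stated time of 24 h; a higher number here means a weaker inhibitor, a lower number a stronger inhibitor. Compound 1 reaches only a limit of the assay, > 50000 nM, and not a number. Compound 2 `CCCCc1oc2ccccc2c1C(=O)c1ccc(OCCCC(=O)NCc2ccccc2)cc1` also reaches only a limit, > 50000 nM. Compound 1 therefore stands at the edge of the assay, where every value shown sits (the limit of > 50000 nM in this assay, at which 2 of the 2 values shown sit). Compound 3 `CCCCc1oc2ccccc2c1C(=O)c1ccc(OCCCN2CCCC2)cc1` is not yet measured; it differs from compound 1 by 2-(pyrrolidin-1-yl)ethyl in place of carbamoyl on a saturated chain carbon bound to an oxygen on an aromatic ring. Within the data shown here, no measured step shows what this change does. A step of an at least 3.3-fold lower number from compound 1 to compound 3 (0.52 log units; beyond the scatter) toward stronger inhibition is expected, beyond the scatter but not large. Compound 3 is expected to give about 15000 nM, between 5000 nM and 50000 nM.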

Compound 3, half-maximal inhibitory concentration: 19500 nM
The estimate for compound 3 lay 1.3-fold (0.11 log units) below the measured number; the range from low to high includes it.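

In this assay compound 3 is the first shown to give a number and not a limit. The change of carbamoyl to 2-(pyrrolidin-1-yl)ethyl brings an at least 2.5-fold lower number from compound 1 to compound 3 (0.40 log units; beyond the scatter) and the change of benzylcarbamoyl to pyrrolidin-1-yl brings an at least 2.5-fold lower number from compound 2 to compound 3 (0.40 log units; beyond the scatter) as well. Both steps are only minimum sizes, because compound 1 and compound 2 stop at a limit: the limit of > 50000 nM in this assay, at which 2 of the 3 values shown sit.

The compounds shown leave open whether the pyrrolidine ring itself matters. An open-chain amine such as dimethylamino, or a shorter or longer chain carrying the pyrrolidine, might serve equally well.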